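The source may hold more compounds than are shown below. What is called first, only, known or untested is meant among the compounds shown, and "the series" means these compounds.

Compound 1 `CCn1c(N)c(-c2nc3ccccc3[nH]2)c2nc(C#N)c(C#N)nc21` gives > 50000 nM
Compound 2 `CN(C)CCn1c(N)c(-c2nc3ccccc3[nH]2)c2nc(C#N)c(C#N)nc21` gives 6340 nM
Compound 3 `N#Cc1nc2c(-c3nc4ccccc4[nH]3)c(N)n(CCN3CCCC3)c2nc1C#N` gives 6480 nM

In a functional assay on K562 cells (Homo sapiens) for antiproliferative activity, read by MTT assay, with a stated time of 48 h (on this read-out higher numbers stand for weaker inhibition and lower numbers for stronger inhibition), the entry for compound 1 (> 50000 nM) is a limit, not a number (the limit of > 50000 nM in this assay, at which 1 of the 3 values shown sits). Compound 3 (6480 nM) stands level with compound 2, within the scatter (a 1.0-fold higher number from compound 2 to compound 3 (0.01 log units; within the scatter)). Compound 4 `CCCn1c(N)c(-c2nc3ccccc3[nH]2)c2nc(C#N)c(C#N)nc21` has methyl in place of pyrrolidin-1-yl on a saturated chain carbon, two bonds along the chain from an aromatic nitrogen. The nearest evidence runs the opposite way: pyrrolidin-1-yl in place of hydrogen gave (an at least 7.7-fold lower number from compound 1 to compound 3 (0.88 log units; beyond the scatter)), and dimethylamino in place of hydrogen gave (an at least 7.8-fold lower number from compound 1 to compound 2 (0.89 log units; beyond the scatter)). Compound 4 carries neither group, so a step of similar size toward a higher number, beyond the scatter, is expected in this assay. The expected step is (a 6.9-fold higher number from compound 3 to compound 4 (0.84 log units; beyond the scatter)). Compound 4 is estimated at 45000 nM (15000 nM to 120000 nM).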

Compound 4, half-maximal inhibitory concentration: > 50000 nM
Compound 4: only a limit was reported; the forecaster's own chance of this, stated with the estimate: 65%; at least 1.1-fold (0.04 log units) between middle value and limit.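

In this assay compound 4 gives > 50000 nM, which is a limit and not a number. Methyl does not stand in for either amine group at this chain carbon, with steps of an at least 7.7-fold higher number from compound 3 to compound 4 (0.88 log units; beyond the scatter) and an at least 7.8-fold higher number from compound 2 to compound 4 (0.89 log units; beyond the scatter), so the lower numbers go with the amine groups rather than with a longer chain alone. The step between compound 1 and compound 4 cannot be read because both entries are limits: the limit of > 50000 nM in this assay, at which 2 of the 4 values shown sit.

From the compounds shown here alone, whether morpholine or a primary amine at this place would keep the lower numbers stays open. So does the effect of a longer chain carrying dimethylamino.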